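The source may hold more compounds than are shown below. What is called first, only, known or untested is meant among the compounds shown, and "the series" means these compounds.

Measured in an assay on CHO-K1 cells for displacement of a labelled ligand from prostaglandin E2 receptor EP1 subtype (Homo sapiens); on this read-out higher numbers stand for weaker inhibition and lower numbers for stronger inhibition:
compound 1 `Cc1cc(C(=O)NCc2ccccc2)nn1Cc1cc(Cl)ccc1OCc1ccccc1` gives 39.8 nM
compound 2 `Cc1cc(C(=O)NCc2ccccn2)nn1Cc1cc(Cl)ccc1OCc1ccccc1` gives 25.1 nM
compound 3 `Cc1cc(C(=O)NCc2cccnc2)nn1Cc1cc(Cl)ccc1OCc1ccccc1` gives 50.1 nM

Compound 3 has the highest of the three numbers, yet its steps to the other two are within the scatter: a 1.3-fold higher number from compound 1 to compound 3 (0.10 log units; within the scatter) and a 2.0-fold higher number from compound 2 to compound 3 (0.30 log units; within the scatter). The three measured compounds do not separate in this assay.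

Compound 4 `Cc1cc(NC(=O)C(C)C)nn1Cc1cc(Cl)ccc1OCc1ccccc1` is not yet measured. It differs from compound 3 by (isopropylcarbonyl)amino in place of ((pyridin-3-yl)methyl)carbamoyl on an aromatic carbon. Going by the values given here, none of the measured steps bears directly on this change. All three steps (a 1.6-fold lower number from compound 1 to compound 2 (0.20 log units; within the scatter), a 1.3-fold higher number from compound 1 to compound 3 (0.10 log units; within the scatter), a 2.0-fold higher number from compound 2 to compound 3 (0.30 log units; within the scatter)) vary only the ring on the saturated chain carbon bound to the amide nitrogen, and all stay within the scatter; none removes the carbamoyl group or that ring. Among the compounds with values here, the series so far shows only that exchanging the ring at that position gives no step beyond the scatter; the change to compound 4 is larger than any of those, and its direction cannot be read from the measured compounds. The expected step from compound 3 to compound 4 is a 4.0-fold higher number from compound 3 to compound 4 (0.60 log units; beyond the scatter), set toward a higher number with a wide range. Compound 4 is expected at 200 nM in this assay, between 30 nM and 2000 nM.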

Compound 4, half-maximal inhibitory concentration: 25.1 nM
For compound 4 the middle estimate is 8.0-fold (0.90 log units) above the measured one, outside the stated range (below it).
By their numbers in this assay, from the lowest: compounds 2, 4, 1 and 3 (each within the scatter of the next).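

In this assay, (isopropylcarbonyl)amino on this aromatic carbon stays within the scatter of all three carbamoyl compounds (a 2.0-fold lower number from compound 3 to compound 4 (0.30 log units; within the scatter); no change at the digits printed from compound 2 to compound 4 (within the scatter); a 1.6-fold lower number from compound 1 to compound 4 (0.20 log units; within the scatter)). At this position, then, neither the carbamoyl orientation nor a ring in the substituent is required to keep the number in the range of the series, since the replacement has no ring and is attached through its nitrogen. The compounds offer no measured basis for explaining this tolerance.

Whether any amide is needed on this carbon stays open, as the compounds shown do not say how a free amine or a carboxylic acid would read there. Also open, from the compounds shown here alone, is whether a longer chain in place of isopropyl would keep the number in this range.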